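Pyridin-2-yl for Phenyl on the Acylurea Nitrogen

The source may hold more compounds than are shown below. What is called first, only, known or untested is meant among the compounds shown, and "the series" means these compounds.

In a functional assay on CCRF-CEM cells (Homo sapiens) for antiproliferative activity, read by MTT assay, with a stated time of 72 h (on this read-out lower numbers stand for stronger inhibition and higher numbers for weaker inhibition), compound 1 `CNC(=O)NC(=O)c1cccc(NC(=O)C(C)Br)c1` gives 9320 nM. Compound 2 `CC(Br)C(=O)Nc1cccc(C(=O)NC(=O)Nc2ccccc2)c1` reaches only a limit of the assay, > 20000 nM. Among the compounds with values here, the one measured step here, an at least 2.1-fold higher number from compound 1 to compound 2 (0.33 log units; beyond the scatter), runs toward the limit of > 20000 nM in this assay, at which 1 of the 2 values shown sits, and leaves compound 2 as the weaker of the two. Compound 3 `CC(Br)C(=O)Nc1cccc(C(=O)NC(=O)Nc2ccccn2)c1` differs from compound 2 by pyridin-2-yl in place of phenyl on an amide-type nitrogen. Within the data shown here, no measured step involves this exchange, so no movement beyond the scatter in this assay is expected, and compound 3 is estimated at 25000 nM (range 8000 nM to 60000 nM), an expected step that the limit leaves unreadable from compound 2 to compound 3.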

Compound 3, half-maximal inhibitory concentration: 6230 nM
Compound 3: middle estimate off by 4.0-fold (0.60 log units), on the high side, outside the stated range (below it).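

On this amide-type nitrogen, pyridin-2-yl in place of phenyl gives an at least 3.2-fold lower number from compound 2 to compound 3 (0.50 log units; beyond the scatter) in this assay, so the loss seen with phenyl does not extend to every six-membered aromatic ring here. Against methyl, pyridin-2-yl gives a 1.5-fold lower number from compound 1 to compound 3 (0.17 log units; within the scatter), so this ring is carried at this place with no change beyond the scatter. Compound 2 stands at a limit, so the first step gives only a bound on the size of the exchange: the limit of > 20000 nM in this assay, at which 1 of the 3 values shown sits.

As far as these compounds go, what pyridin-3-yl, pyridin-4-yl or a longer chain would do on this nitrogen remains open. So does whether the ring nitrogen itself accounts for the difference from phenyl.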